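The source may hold more compounds than are shown below. What is called first, only, known or untested is meant among the compounds shown, and "the series" means these compounds.

Of the compounds shown here, two of a shared core have been measured here. Compound 1 `O=c1cc(NC2CCCCC2)cc(/C=C/c2ccccc2)o1` gives in a functional assay on A549 cells (Homo sapiens) for cytotoxicity, read by MTT assay, with a stated time of 72 h (a lower number here means that less compound is needed, a higher number that more compound is needed for the effect), a value of 1.25 uM. Compound 2 `COc1ccc(Nc2cc(C)oc(=O)c2)cc1` is recorded only as a limit of this assay, not as a number: in this assay compound 2 gives > 30 uM. Compound 2 thus stands at the limit of > 30 uM in this assay, at which 1 of the 2 values shown sits, and no finite value is known for it.

Compound 3 `CCCCCc1cc(Nc2ccc(OC)cc2)cc(=O)o1` differs from compound 2 in one place: butyl in place of hydrogen on a saturated chain carbon bound to an aromatic carbon. Among the measured compounds shown here, no step between two measured compounds is available for this change, so its size is not known from the data; the longer chain of compound 3 is simply an extension of the group that compound 2 carries.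

It is estimated that the step from compound 2 to compound 3 in this assay amounts to an at least 2.5-fold lower number from compound 2 to compound 3 (0.39 log units; beyond the scatter), toward a lower concentration. For compound 3 the expected value in this assay is 12 uM, with a range from 3 uM to 40 uM.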

Compound 3, concentration for half-maximal effect: 4.42 uM
Compound 3: the middle estimate sits 2.7-fold (0.43 log units) above what was measured, within the range that was stated.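

The pentyl chain of compound 3 shows that this position, a saturated chain carbon bound to an aromatic carbon, responds in this assay to lengthening the chain: the change of methyl to pentyl gives an at least 6.7-fold lower number from compound 2 to compound 3 (0.83 log units; beyond the scatter) and so moves the value beyond the scatter. Compound 2 is recorded only as a limit of the assay, > 30 uM, and not as a number. The step is therefore a bound on the change, and its true size stays unknown because compound 2 has no finite value: the limit of > 30 uM in this assay, at which 1 of the 3 values shown sits.

The compounds shown leave open whether a shorter chain such as propyl, a longer chain such as heptyl, or a hydroxyl at the chain end would lower the number further or raise it again. Among the compounds shown here, compound 1 differs from compound 3 in more than one place, so it gives no step for this change.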